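The source may hold more compounds than are shown below. What is called first, only, known or untested is meant among the compounds shown, and "the series" means these compounds.

Of the compounds shown here, three have been measured in a physicochemical assay for lipophilicity; on this read-out higher numbers stand for higher lipophilicity and lower numbers for lower lipophilicity: compound 1 `Cc1cnc(NC(=O)[C@H](COC(C)C)Oc2ncnc3c2cnn3-c2ccccc2Cl)cn1` gives 2.1, compound 2 `CC(C)OC[C@H](Oc1ncnc2c1cnn2-c1ccccc1Cl)C(=O)Nc1ccc(C#N)cn1` gives 3.5 and compound 3 `Cc1ccc(NC(=O)[C@H](COC(C)C)Oc2ncnc3c2cnn3-c2ccccc2Cl)nc1` gives 3.9. Compound 2 is therefore second highest of the three. Compound 4 `CC(C)OC[C@H](Oc1ncnc2c1cnn2-c1ncccc1Cl)C(=O)Nc1ccc(C#N)cn1` has 3-chloropyridin-2-yl in place of 2-chlorophenyl on an aromatic nitrogen. Among the measured compounds shown here, no measured step covers this exact exchange. The nearest guides are the large steps of a number 1.80 log units higher from compound 1 to compound 3 (beyond the scatter) and a number 1.40 log units higher from compound 1 to compound 2 (beyond the scatter), which both remove a ring nitrogen on the group at the amide-type nitrogen. The modest step of a number 0.40 log units higher from compound 2 to compound 3 (beyond the scatter) swaps methyl and cyano and bears little on this change. Adding a ring nitrogen here is expected to give a large drop in this assay. The expected step is a number 1.00 log units lower from compound 2 to compound 4 (beyond the scatter). Compound 4 is estimated at 2.5, with an expected range of 1.9 to 3.1.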

Compound 4, distribution coefficient: 2.5
Compound 4: the middle estimate sits on the measured number at the digits printed, and the stated range covers the measured number.
By their numbers in this assay, from the lowest: compound 1; then compound 4; then compound 2; then compound 3.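

On an aromatic nitrogen of the five-membered ring, 3-chloropyridin-2-yl in place of 2-chlorophenyl gives, in this assay, a number 1.00 log units lower from compound 2 to compound 4 (beyond the scatter). Among the compounds shown here, the earlier steps all lay at the amide-type nitrogen, so this is the first sign that this assay also responds to a change at this position. Nothing at hand accounts for the size of this step.

Open, on these data alone, is whether the same exchange gives a similar step with 5-methylpyridin-2-yl on the amide-type nitrogen. Also open, as far as these compounds go, is what an amine or a carboxylic acid in place of the chlorine would do.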